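This account rests on a few compounds, and the source may have more. Where it says the series, first, only, none or still open, it means among the compounds named here.

Measured so far in an ADME assay on MCF10 cells (Homo sapiens) for cytotoxicity (on this read-out higher numbers stand for weaker inhibition and lower numbers for stronger inhibition), for this series:
- Compound 1 `CCc1nc(N)nc(N)c1C#CC(C)c1ccc(-c2ccc(O)cc2)cc1OC` gives 148000 nM as its result
- Compound 2 `CCc1nc(N)nc(N)c1C#CC(C)c1ccc(-c2ccc(C)cc2)cc1OC` gives "not determined" (no result reported) as its result

In this assay compound 2 has "not determined" (no result reported) as its only entry, so it offers no figure to start from, and only compound 1 has a number, namely 148000 nM on this scale.

Compound 3 `CCc1nc(N)nc(N)c1C#CC(C)c1ccc(-c2ccc(F)cc2)cc1OC` has yet to be measured. The change is fluoro in place of methyl on an aromatic carbon with fluoro in place of methyl on an aromatic carbon, para to a large group, which reads, cut one bond further out, as 4-methylphenyl to 4-fluorophenyl.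

Within the data shown here, no pair of measured compounds shows a step, so the expected size cannot be read from the data. In this assay no step beyond the usual scatter is expected for this swap, and neither direction is favoured. Among the measured compounds shown here, the sole guide is compound 1 at 148000 nM in the same series, which suggests a similarly weak reading. Compound 3 is expected to give about 120000 nM with an estimated range from 50000 nM to 300000 nM in this measurement.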

Compound 3, half-maximal inhibitory concentration: 60000 nM
Compound 3: middle estimate off by 2.0-fold (0.30 log units), on the high side, and the stated range covers the measured number.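

In this assay, among these compounds, exchanging hydroxy for fluoro gives a 2.5-fold lower number from compound 1 to compound 3 (0.39 log units; beyond the scatter), the first readable step, which shows that the read-out responds to the group at this position, though only modestly, with the lower number standing for stronger inhibition. Going by these compounds, compound 2 has no number, so the step from methyl to fluoro cannot be read, and the methyl group's place relative to the hydroxy and fluoro groups remains unknown. Nothing shown here accounts for the step between hydroxy and fluoro.

The compounds shown leave open whether the lower number belongs to fluoro itself or would also appear with other groups in the same place, such as chloro, methoxy, an amine or a carboxylic acid. Among the compounds shown here, they also leave open whether the same swap would give a step of similar size on a different core, since this single pair is the only comparison available at this position.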